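The source may report more compounds than this note shows. Statements on the series, on what has been measured and on what is new or still open speak of the compounds shown alone.

Among the compounds with values here, in a functional assay on ACHN cells (Homo sapiens) for inhibition, read by sulforhodamine B assay (a lower number here means a stronger inhibitor of growth, a higher number a weaker inhibitor of growth), compound 1 `COc1cccc(CN2CCC=C(CCC(=O)NO)C2=O)c1` gives 7600 nM, the only number available. For compound 2 `O=C(CCC1=CCCN(Cc2ccc(F)cc2)C1=O)NO` the result reads "not determined" (no result reported). For compound 3 `O=C(CCC1=CCCN(Cc2ccc3ccccc3c2)C1=O)NO` the result also reads "not determined" (no result reported). Compound 2 therefore cannot be placed on the scale and offers no direct baseline. Compound 4 `O=C(CCC1=CCCN(Cc2ccc(NC(=O)c3ccccc3)cc2)C1=O)NO` has not yet been measured. The structural step is benzamido in place of fluoro on an aromatic carbon, para to a large group. Within the data shown here, no step between measured compounds exists to show how much such a change matters in this assay. The expectation therefore rests on compound 1 at 7600 nM as the sole anchor, and it is a tentative one: a moderate shift towards stronger growth inhibition, beyond the usual scatter but with considerable uncertainty. The estimate for compound 4 is 3000 nM, with an expected range of 600 nM to 15000 nM.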

Compound 4, concentration for 50% growth inhibition: > 10000 nM
Compound 4: no number, only a limit (the forecaster's own chance of this, stated with the estimate: 10%); middle value at least 3.3-fold (0.52 log units) from the limit.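

In this assay compound 4 gives > 10000 nM, a limit and not a number. Within the data shown here, compound 2 has no single number, so no step from it to compound 4 can be read. The compounds shown leave open what benzamido in place of fluoro does to growth inhibition in this assay.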